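Methoxy addition on a weak indole series: an expected step

A few compounds are considered here, and "the series" means these few. Any claim that something is new, unique, unknown or untested is made for them only; others in the source may bear on it.

Measured compounds:
compound 1 `COc1ccc2[nH]cc(C(=O)c3cc(OC)c(OC)c(OC)c3N)c2c1`, 950 nM
compound 2 `COc1cc2[nH]cc(C(=O)c3cc(OC)c(OC)c(OC)c3N)c2cc1OC`, 24400 nM
compound 3 `COc1ccc2c(Cc3cc(OC)c(OC)c(OC)c3N)c[nH]c2c1`, 74800 nM

In a functional assay on HT-29 cells (Homo sapiens) for cytotoxicity, read by sulforhodamine B assay, with a stated time of 48 h (a higher number here means a weaker inhibitor of growth, a lower number a stronger inhibitor of growth), compound 1 gives 950 nM. Compound 2 differs from it by one change, (methoxy in place of hydrogen on an aromatic carbon), and this gives a 26-fold higher number from compound 1 to compound 2 (1.41 log units; beyond the scatter). Compound 3 carries a different core; the difference between the core of compound 3 and the core of compound 1 is not broken down here. In this assay compound 3 gives 74800 nM, the highest of the three numbers.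

Compound 4 `COc1cc2[nH]cc(Cc3cc(OC)c(OC)c(OC)c3N)c2cc1OC` is not yet measured. It is made from compound 3 by methoxy in place of hydrogen on an aromatic carbon, the same change as from compound 1 to compound 2, made at the same kind of place. Because of a 26-fold higher number from compound 1 to compound 2 (1.41 log units; beyond the scatter), compound 4 is expected to give a higher number than compound 3, estimated as a 5.3-fold higher number from compound 3 to compound 4 (0.73 log units; beyond the scatter), though the step may be cut short where the assay reaches its limit. In this assay compound 4 is expected to give about 400000 nM, between 100000 nM and 2000000 nM.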

Compound 4, concentration for 50% growth inhibition: "not active" (no number reported)
For compound 4 the study gives words and no number, so the estimate cannot be set against anything.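

In this assay, for the compounds shown here, compound 4 is reported only as "not active", with no number, so no step from compound 3 to compound 4 can be read. The compounds shown leave open how far the added methoxy shifts growth inhibition on the core of compound 3. No measured evidence here bears on this result.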